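A few compounds are considered here, and "the series" means these few. Any claim that something is new, unique, unknown or untested is made for them only; others in the source may bear on it.

Working notes on the series. Compound 1 `O=C(COCc1ccccc1)N1CCN(c2ccc(Cl)cc2)CC1` gives 350 nM in a functional assay on HEK293 cells for positive allosteric modulation of metabotropic glutamate receptor 5 (Homo sapiens), read by FLIPR and calcium flux; on this read-out lower numbers stand for an effect already at smaller amounts and higher numbers for an effect only at larger amounts of compound. Within the data shown here, compound 2 `O=C(COCc1ncccn1)N1CCN(c2ccc(Cl)cc2Cl)CC1` gives 18000 nM in the same assay, the highest of the two numbers so far; compound 1 shows a lower number, a gap beyond the usual scatter. Compound 3 `O=C(CSc1ccccc1)N1CCN(c2ccc(Cl)cc2Cl)CC1` has not yet been measured. It differs from compound 2 in that (phenylsulfanyl in place of (pyrimidin-2-yl)methoxy on a saturated chain carbon bound to a carbonyl carbon). Since this restores a carbon-only aromatic ring as in compound 1, whose value is 350 nM, a move toward lower numbers beyond the scatter is expected, as the step of a 12-fold lower number from compound 2 to compound 3 (1.08 log units; beyond the scatter). The estimate for compound 3 is 1500 nM, with an expected range of 400 nM to 6000 nM.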

Compound 3, half-maximal effective concentration: > 25000 nM
Compound 3: a limit, no number; the forecaster's own chance of this, stated with the estimate: 10%; middle value at least 16-fold (1.22 log units) from the limit.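

In this assay compound 3 gives > 25000 nM, a limit of the assay and not a number. The change at this place, phenylsulfanyl in place of (pyrimidin-2-yl)methoxy on a saturated chain carbon bound to a carbonyl carbon, gives an at least 1.3-fold higher number from compound 2 to compound 3 (0.14 log units; that floor lies within the scatter). On these data alone, a carbon-only aromatic ring here therefore brings no lower number on the core shared by compound 2 and compound 3, and the true size of the step stays unknown.

The compounds shown leave open what a phenoxy or a 2-phenylethyl group would give at this place.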